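This account rests on a few compounds, and the source may have more. Where it says the series, first, only, none or still open, it means among the compounds named here.

Of the compounds shown here, two have been measured in a functional assay (trachea) with Cavia porcellus as the target (on this read-out lower numbers stand for an effect already at smaller amounts and higher numbers for an effect only at larger amounts of compound), so far. Compound 1 `CCCn1c(=O)n(CCC(=O)O)c(=O)c2[nH]cnc21` gives 21200 nM in this read-out, while compound 2 `CCCn1cnc2c1c(=O)n(C)c(=O)n2CCC` gives 5000 nM as the lower of the two numbers, with a gap beyond the usual scatter. Compound 3 `CCCn1c(=O)n(C)c(=O)c2c1ncn2CC(N)=O` has not yet been measured. It differs from compound 2 by carbamoyl in place of ethyl on a saturated chain carbon bound to an aromatic nitrogen, so that propyl becomes carbamoylmethyl (carbamoyl in place of ethyl on a saturated chain carbon bound to an aromatic nitrogen). Going by the values given here, no measured step covers this change, so the expectation remains loose. In this assay a step beyond the scatter toward a higher number is expected, with compound 1 at 21200 nM as the only higher reference point. The estimated step is a 4.0-fold higher number from compound 2 to compound 3 (0.60 log units; beyond the scatter) and is expected to run upward. Compound 3 is expected at about 20000 nM in an estimated range of 7000 nM to 60000 nM for this read-out.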

Compound 3, half-maximal effective concentration: > 100000 nM
Compound 3 was reported as a limit (the forecaster's own chance of this, stated with the estimate: 15%); middle value at least 5.0-fold (0.69 log units) from the limit.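

In this assay, going by these compounds alone, the change from propyl to carbamoylmethyl on a saturated chain carbon bound to an aromatic nitrogen gives an at least 20-fold higher number from compound 2 to compound 3 (1.30 log units; beyond the scatter), the first step at this place that can be read on its own. Compound 3 gives > 100000 nM, which is a limit of the assay and not a number. This single change is thus enough to move the read-out well beyond the scatter, something the two earlier compounds could not show, as they differ in more than one place.

On these data alone, how far the true value of compound 3 lies past this limit stays open: the limit of > 100000 nM in this assay, at which 1 of the 3 values shown sits. As far as these compounds go, it also stays open whether the rise follows from the carbamoyl group itself or from the loss of the propyl chain, and an amine, a hydroxyl group or a butyl chain at this place would bear on that.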